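Opening the cyclopentyl ring: a pentan-3-yl swap

The compounds below may be only part of what the source reports. "The series", "measured", "known", "first", "only" and "open" are said of these compounds alone.

Measured so far:
compound 1 `O=C(/C=C/c1ccc(O)cc1)c1c(O)cccc1OCC1CCCC1`: 2140 nM
compound 2 `CC(C)(C)CCOc1cccc(O)c1C(=O)CCc1ccc(O)cc1`: > 30000 nM

Going by the values given here, in a functional assay on NUGC-3 cells (Homo sapiens) for antiproliferative activity, read by sulforhodamine B assay (a higher number here means a weaker inhibitor of growth, a lower number a stronger inhibitor of growth), compound 1 gives 2140 nM, the only definite number among the two values. Among the compounds with values here, for compound 2 this assay reports > 30000 nM, which is a limit of the assay and not a number; it is the one value sitting at the limit of > 30000 nM in this assay, at which 1 of the 2 values shown sits. Within the data shown here, compound 2 differs from compound 1 in more than one place, so no single step links the two, and their values show only that compound 1 inhibits growth measurably while compound 2 does not within the assay's reach.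

Compound 3 `CCC(CC)COc1cccc(O)c1C(=O)/C=C/c1ccc(O)cc1` keeps the shared core of compound 1 and changes one group: pentan-3-yl in place of cyclopentyl on a saturated chain carbon bound to an oxygen on an aromatic ring. Both groups carry the same count of heavy atoms, the same donors and acceptors, and no charge. Among the measured compounds shown here, with no measured step to lean on, the step of a 1.3-fold higher number from compound 1 to compound 3 (0.12 log units; within the scatter) is expected to stay within the usual scatter. Compound 3 is therefore estimated at 2800 nM, with a range from 900 nM to 9000 nM.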

Compound 3, concentration for 50% growth inhibition: 1960 nM
Beside the measured number, compound 3's estimate is 1.4-fold (0.15 log units) above it; low and high end bracket the measured number.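

Putting pentan-3-yl in place of cyclopentyl gives a 1.1-fold lower number from compound 1 to compound 3 (0.04 log units; within the scatter) in this assay, so the two compounds cannot be told apart in this test of growth inhibition. Going by these compounds alone, this is the first direct reading at this place, on a saturated chain carbon bound to an oxygen on an aromatic ring: for this pair, the closed five-membered ring can be opened with no change beyond the scatter. Nothing among the measurements shown gives a reason for this outcome.

The compounds shown leave open how a much shorter group such as methyl, or a longer chain such as n-octyl, would read at this place. They also leave open whether a group carrying an amine or a carboxylic acid would keep the growth inhibition seen with compound 3.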